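Moving the chlorine on the anilino ring of a quinazoline

This account rests on a few compounds, and the source may have more. Where it says the series, first, only, none or still open, it means among the compounds named here.

Measured so far:
compound 1, `COc1ccccc1Nc1nc(-c2cccc(F)c2)nc2ccc(F)cc12` — > 50000 nM
compound 2, `Fc1cccc(-c2nc(Nc3ccc(Cl)cc3)c3cc(F)ccc3n2)c1` — 45700 nM

Compound 1 shows only a limit in a functional assay on HL-60 cells (Homo sapiens) for cytotoxicity, read by MTT assay, with a stated time of 48 h (on this read-out lower numbers stand for stronger inhibition and higher numbers for weaker inhibition), namely > 50000 nM; that is the limit of > 50000 nM in this assay, at which 1 of the 2 values shown sits. Among the compounds with values here, compound 2 is the only compound with a number in this assay, where compound 2 gives 45700 nM. Within the data shown here, the single measured step, an at least 1.0-fold lower number from compound 1 to compound 2 (0.03 log units; that floor lies within the scatter), lies at its floor, within the scatter, so the two compounds cannot be ordered.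

Compound 3, `Fc1cccc(-c2nc(Nc3ccccc3Cl)c3cc(F)ccc3n2)c1`, differs from compound 2 by 2-chlorophenyl in place of 4-chlorophenyl on a nitrogen on an aromatic ring. Among the measured compounds shown here, no measured step moves a substituent around the same ring, so the step from compound 1 to compound 2 bears on it only in showing that a change on this nitrogen left this assay essentially unmoved. Compound 3 is therefore expected to give 42000 nM, between 15000 nM and 60000 nM, meaning a step of a 1.1-fold lower number from compound 2 to compound 3 (0.04 log units; within the scatter), within the scatter, with a fair chance that this assay again reports only a limit.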

Compound 3, half-maximal inhibitory concentration: > 50000 nM
Compound 3 was reported as a limit (the forecaster's own chance of this, stated with the estimate: 40%); middle value at least 1.1-fold (0.07 log units) away from the limit.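

Placing the chlorine as 2-chlorophenyl rather than 4-chlorophenyl on this nitrogen gives an at least 1.0-fold higher number from compound 2 to compound 3 (0.03 log units; that floor lies within the scatter), so in this assay this move of one atom around the ring cannot be told apart from no change. Within the data shown here, the step between compound 1 and compound 3 joins two limits and cannot be read, which leaves compound 2 as the only compound with a number. The new result adds a second compound at the ceiling of this assay, and the series now mostly gives limits rather than numbers: the limit of > 50000 nM in this assay, at which 2 of the 3 values shown sit.

Going by these compounds, what stays open is whether any group on this ring can give a number clearly lower than that of compound 2 in this assay. An amine or a carboxylic acid in place of the chloro group would test this.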